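Moving the Methyl on the Phenyl Ring of Compound 2

This account rests on a few compounds, and the source may have more. Where it says the series, first, only, none or still open, it means among the compounds named here.

Two measured compounds share one core and differ in a single group. Compound 1 `CCOC(=O)c1sc(Nc2cccnc2Oc2ccccc2C(C)(C)C)nc1C(F)(F)F` carries an ethoxycarbonyl group at that position, and in an assay on HEK293 cells for displacement of a labelled ligand from P2Y purinoceptor 1 (Homo sapiens), read by scintillation counting, with a stated time of 1 h (a higher number here means a weaker inhibitor, a lower number a stronger inhibitor), compound 1 gives 5 nM. Compound 2 `Cc1ccccc1-c1sc(Nc2cccnc2Oc2ccccc2C(C)(C)C)nc1C(F)(F)F` carries a 2-methylphenyl group there instead, and in this assay compound 2 gives 11 nM. For the measured compounds named here, the only measured step is a 2.2-fold higher number from compound 1 to compound 2 (0.34 log units; beyond the scatter), so compound 2 holds the higher of the two numbers and is the weaker of the pair.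

Compound 3 `Cc1ccc(-c2sc(Nc3cccnc3Oc3ccccc3C(C)(C)C)nc2C(F)(F)F)cc1` keeps the same atoms and only shifts the methyl group on the phenyl ring: 4-methylphenyl in place of 2-methylphenyl on an aromatic carbon. Going by the values given here, no measured step bears on this change directly; the one step known swaps the whole group rather than moving a methyl within it, so it gives no guide to direction. With nothing pointing either way, the expected step of a 1.3-fold higher number from compound 2 to compound 3 (0.10 log units; within the scatter) in this assay is one that stays within the scatter. Compound 3 is therefore estimated at 14 nM in this assay, with a range from 5 nM to 45 nM.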

Compound 3, inhibition constant: 8 nM
For compound 3 the middle estimate is 1.8-fold (0.24 log units) above the measured one; low and high end bracket the measured number.
By their numbers in this assay, from the lowest: compounds 1, 3 and 2 (each within the scatter of the next, the first and the last beyond it).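

Moving the methyl from 2-methylphenyl to 4-methylphenyl, on the aromatic carbon next to the ring sulfur, gives a 1.4-fold lower number from compound 2 to compound 3 (0.14 log units; within the scatter) in this assay, so the two arrangements cannot be told apart by this measurement. The swap from the ethoxycarbonyl group to 4-methylphenyl gives a 1.6-fold higher number from compound 1 to compound 3 (0.20 log units; within the scatter) and stays inside the usual scatter, while the swap to 2-methylphenyl gave a 2.2-fold higher number from compound 1 to compound 2 (0.34 log units; beyond the scatter) and lay beyond it, so the one clear gap seen earlier does not carry over to both methylphenyl groups. Nothing given here explains these numbers or says what lies behind them.

With only three compounds, all of them close in value, the limits of what this position accepts remain unknown, since each group shown here is either an ester or a methylphenyl. A plain phenyl group, a methoxy or chlorine on the phenyl ring, and a carboxylic acid, an amine or a longer alkyl chain at the same carbon would each show whether the numbers stay this close or move well beyond the scatter.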